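The source may hold more compounds than are shown below. What is called first, only, known or untested is meant among the compounds shown, and "the series" means these compounds.

Among the compounds with values here, compound 1 `CCC(C)(C)Cc1c[nH]c(CCc2ccc(-c3cccc(C)n3)cc2)n1` carries a 6-methylpyridin-2-yl group and, in a functional assay on HEK293 cells for agonist activity at Bombesin receptor subtype-3 (Homo sapiens), read by luminescence and calcium flux, with a stated time of 10 min (a higher number here means that more compound is needed for the effect, a lower number that less compound is needed), compound 1 gives 105 nM, the lowest of the three numbers measured so far. Compound 2 `CCC(C)(C)Cc1c[nH]c(CCc2ccc(-c3ccncc3)cc2)n1` gives 305 nM and compound 3 `CCC(C)(C)Cc1c[nH]c(CCc2ccc(-c3cnccn3)cc2)n1` gives 431 nM. Both replacements of the 6-methylpyridin-2-yl group raised the number, a 2.9-fold higher number from compound 1 to compound 2 (0.46 log units; beyond the scatter) and a 4.1-fold higher number from compound 1 to compound 3 (0.61 log units; beyond the scatter), whereas a 1.4-fold higher number from compound 2 to compound 3 (0.15 log units; within the scatter). Compound 4 `CCC(C)(C)Cc1c[nH]c(CCc2ccc(-c3ccns3)cc2)n1` makes a change of the same kind at the same place: 1,2-thiazol-5-yl in place of 6-methylpyridin-2-yl on an aromatic carbon. Both measured steps away from compound 1 bear on this change and were modest rises, so a modest rise beyond the scatter is expected here as well. Compound 4 is therefore estimated at 350 nM, with a range from 120 nM to 1000 nM, which means a 3.3-fold higher number from compound 1 to compound 4 (0.52 log units; beyond the scatter) is expected.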

Compound 4, half-maximal effective concentration: 63 nM
Compound 4: the middle estimate sits 5.6-fold (0.74 log units) above what was measured, outside the stated range (below it).
By their numbers in this assay, from the lowest: compounds 4 and 1 (each within the scatter of the next); then compounds 2 and 3 (each within the scatter of the next).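

In this assay, the 1,2-thiazol-5-yl group shows that this place, para to a large group, does not depend on the 6-methylpyridin-2-yl group: a 1.7-fold lower number from compound 1 to compound 4 (0.22 log units; within the scatter). It also separates five-membered from six-membered replacements here, with a 6.8-fold lower number from compound 3 to compound 4 (0.84 log units; beyond the scatter) and a 4.8-fold lower number from compound 2 to compound 4 (0.68 log units; beyond the scatter). Within the data shown here, compound 4 is the first replacement that does not raise the number from compound 1.

Nothing measured explains why this ring matches the 6-methylpyridin-2-yl group while pyridin-4-yl and pyrazin-2-yl do not. On these data alone, whether a thiophene ring, a 1,3-thiazole ring or a methyl group on the 1,2-thiazol-5-yl ring would hold this level stays open.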